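This account rests on a few compounds, and the source may have more. Where it says the series, first, only, none or still open, it means among the compounds named here.

Compound 1 `Nc1nc2c(ncn2/C=C2\C[C@H]2[C@@H](O)CO)c(=O)[nH]1` gives 75000 nM in an ADME assay on Akata cells (Homo sapiens) for cytotoxicity; on this read-out lower numbers stand for higher toxicity in this test and higher numbers for lower toxicity in this test. Compound 2 `Nc1ncnc2c1ncn2/C=C1\C[C@H]1[C@H](O)CO` gives 72700 nM in this assay.

Compound 1 holds the highest of the two numbers in this assay, with compound 2 sitting so close that the two values lie within the usual scatter and cannot be told apart. Both values are high, meaning neither compound harms these cells until a large amount is present.

Compound 3 `Nc1nc2c(ncn2/C=C2/C[C@H]2[C@H](O)CO)c(=O)[nH]1` is the next compound in this series and has not yet been measured in this assay. Compared with compound 1, (the two compounds have the same atoms and bonds and differ only in configuration as drawn: 2 of 3 stereo elements differ; a stereocentre at a saturated chain carbon is drawn R in compound 1 and S in compound 3; a double bond is drawn E in compound 1 and Z in compound 3). Going by the values given here, no step between two measured compounds with such a change is available, so the expected size of the step rests on the two measured values alone, which show little spread.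

The step from compound 1 to compound 3 in this assay is expected to be small, a 1.1-fold lower number from compound 1 to compound 3 (0.03 log units; within the scatter), with no clear direction beyond the scatter. Compound 3 is therefore expected to give about 70000 nM in this assay, with a range from 30000 nM to 160000 nM.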

Compound 3, half-maximal cytotoxic concentration: 62600 nM
For compound 3 the middle estimate is 1.1-fold (0.05 log units) above the measured one, within the range that was stated.
By their numbers in this assay, from the lowest: compounds 3, 2 and 1 (each within the scatter of the next).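

In this assay, moving the stereocentre at the saturated chain carbon from R to S and the double bond from E to Z together gives a 1.2-fold lower number from compound 1 to compound 3 (0.08 log units; within the scatter). Going by these compounds alone, this is the first step that can be read, and it shows that this double change in configuration leaves the read-out within the scatter, so the test does not tell these two arrangements apart. The comparison is a clean one, and it rests on a single fact: the fact that compounds 1 and 3 differ only in the configuration as drawn.

On these data alone, the two stereo elements changed together, so the effect of each one alone stays unknown, and two separate effects that offset each other cannot be ruled out. As far as these compounds go, how the read-out responds to a new group on the shared core, such as a carboxylic acid or a longer chain, also stays open.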